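Dropping Two Chlorines from a Dihydrofolate Reductase Inhibitor

The source may report more compounds than this note shows. Statements on the series, on what has been measured and on what is new or still open speak of the compounds shown alone.

Four compounds share one core and differ in the ring hung from a three-carbon linker. Compound 1 `NC1=NC2(CCSCC2)N(OCCCOc2cccc(Cl)c2)C(N)=N1` and compound 2 `NC1=NC2(CCOCC2)N(OCCCOc2cccc(Cl)c2Cl)C(N)=N1` were both examined in an assay on isolated protein for inhibition of Dihydrofolate reductase (Homo sapiens), read by spectrophotometry, using NADPH, with stated times of 5 s and 6 min (a higher number here means a weaker inhibitor, a lower number a stronger inhibitor), yet for neither was a result reported. In this assay the entry for compound 1 reads "not determined" (no result reported). In this assay the entry for compound 2 reads "not determined" (no result reported), so compound 2 has no number to stand on, and compound 1 is in the same position. Among the measured compounds shown here, compound 3 `NC1=NC2(CCSCC2)N(OCCCOc2ccc(Br)cc2)C(N)=N1` is the only one with a value: in this assay compound 3 gives 6.46 nM. Compound 4 `NC1=NC2(CCOCC2)N(OCCCOc2ccccc2)C(N)=N1` has not yet been tested in this assay.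

The change from compound 2 to compound 4 is phenyl in place of 2,3-dichlorophenyl on an oxygen on a saturated carbon. For the measured compounds named here, no measured pair shows a step of this kind, so its size is unknown. The expectation is a move toward weaker inhibition, of modest size, mainly because compound 3 gives 6.46 nM while keeping a halogen on its ring. Compound 4 is therefore expected to reach about 30 nM in this assay, plausibly between 8 nM and 150 nM.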

Compound 4, half-maximal inhibitory concentration: 86.1 nM
Beside the measured number, compound 4's estimate is 2.9-fold (0.46 log units) below it; low and high end bracket the measured number.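

Compound 2 carries no single number to set against compound 4, so no step between them can be read, and nothing at hand explains the result. The compounds shown leave open how far phenyl in place of 2,3-dichlorophenyl shifts inhibition in this assay.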